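A Phenoxy Group Enters Where Dichlorophenyl Stood

The source may report more compounds than this note shows. Statements on the series, on what has been measured and on what is new or still open speak of the compounds shown alone.

Compound 1 `CCc1cc(Cl)c(S(C)(=O)=O)cc1C(=O)N=C(N)N`: 63 nM
Compound 2 `Cc1c(C(=O)N=C(N)N)cc(S(C)(=O)=O)c(C)c1C`: 55 nM
Compound 3 `Cc1cc(-c2ccc(Cl)cc2Cl)c(S(C)(=O)=O)cc1C(=O)N=C(N)N`: 42 nM

Of the compounds shown here, three have been measured in a functional assay for inhibition of sodium/hydrogen exchanger (Oryctolagus cuniculus); a higher number here means a weaker inhibitor, a lower number a stronger inhibitor. Compound 3 gives the smallest of the three numbers, but its gaps to compound 2 and to compound 1 both lie within the usual scatter of repeated measurements, so the three compounds stand level and no one of them can be called stronger or weaker than the others.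

The next compound, compound 4 `Cc1cc(Oc2ccccc2)c(S(C)(=O)=O)cc1C(=O)N=C(N)N`, differs from compound 3 in one place: phenoxy in place of 2,4-dichlorophenyl on an aromatic carbon. Among the compounds with values here, no two of the measured compounds differ in one place only, so no measured step shows what such a change does here. What the three numbers do show is that the group at this position, whether a small one as in compound 1 or a larger one as in compound 3, has left the number much where it is.

On that basis compound 4 is expected to give a number close to that of compound 3, with the step of a 1.4-fold higher number from compound 3 to compound 4 (0.15 log units; within the scatter) expected to stay within the scatter. The estimate for compound 4 in this assay is 60 nM, with a range from 20 nM to 200 nM.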

Compound 4, half-maximal inhibitory concentration: 10 nM
The estimate for compound 4 lay 6.0-fold (0.78 log units) above the measured number, and the stated range ends above it.
By their numbers in this assay, from the lowest: compound 4; then compounds 3, 2 and 1 (each within the scatter of the next).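

In this assay, within the data shown here, the exchange of 2,4-dichlorophenyl for phenoxy gives a 4.2-fold lower number from compound 3 to compound 4 (0.62 log units; beyond the scatter) and so provides the first measured step in this set that lies beyond the scatter. The three earlier compounds stood level and suggested that the group on this aromatic carbon, ortho to the methylsulfonyl group, mattered little, but this single step shows that the number does respond to what is placed there, even when the entering and leaving groups are close in heavy-atom count and each carries one six-membered aromatic ring of carbon only. Nothing at hand bears on why the number moves in this way.

The step also combines two differences, as the two chlorines leave and an oxygen enters, and these compounds cannot show how much of the step belongs to either one. An unsubstituted phenyl group or a 2,4-dichlorophenoxy group at this position would separate the two, while an anilino or benzyl group would show whether the oxygen itself can be replaced by a nitrogen or a carbon.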